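One Fluorine Fewer on the Trifluoromethyl Group

The source may hold more compounds than are shown below. What is called first, only, known or untested is meant among the compounds shown, and "the series" means these compounds.

Measured in a functional assay on MIA PaCa-2 cells (Homo sapiens) for inhibition, read by MTT assay, with a stated time of 7 days; a higher number here means a weaker inhibitor, a lower number a stronger inhibitor:
Compound 1 `O=C([C@@H]1CCCN(S(=O)(=O)c2ccc(S(=O)(=O)N3CC[C@@H](O)C3)cc2)C1)N1CCC(F)(F)CC1` gives 210 nM.
Compound 2 `O=C([C@@H]1CCCN(S(=O)(=O)c2ccc(S(=O)(=O)N3CC[C@H](O)C3)cc2)C1)N1CCC(F)(F)CC1` gives 590 nM.
Compound 3 `CCN(CC)S(=O)(=O)c1ccc(S(=O)(=O)N2CCC[C@@H](C(=O)N3CCC(C(F)(F)F)CC3)C2)cc1` gives 320 nM.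

Compound 3 stands second highest of the three numbers; compound 1 is nearest with a lower number, compound 2 furthest with a higher number, and both gaps lie within the scatter. Compound 4 `CCN(CC)S(=O)(=O)c1ccc(S(=O)(=O)N2CCC[C@@H](C(=O)N3CCC(C(F)F)CC3)C2)cc1` differs from compound 3 by hydrogen in place of fluoro on a saturated chain carbon bound to two fluorine atoms and a saturated ring carbon. Among the compounds with values here, the only measured step, a 2.8-fold higher number from compound 1 to compound 2 (0.45 log units; beyond the scatter), concerns a change in configuration alone (the fact that compounds 1 and 2 differ only in the configuration as drawn), so no measured step bears on removing a fluoro. With nothing to point either way, the step of a 1.1-fold higher number from compound 3 to compound 4 (0.04 log units; within the scatter) is expected to stay within the scatter. Compound 4 is therefore estimated at 350 nM, with a range from 150 nM to 800 nM.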

Compound 4, half-maximal inhibitory concentration: 420 nM
Compound 4: the middle estimate sits 1.2-fold (0.08 log units) below what was measured; measured number inside the range.
By their numbers in this assay, from the lowest: compounds 1, 3, 4 and 2 (each within the scatter of the next, the first and the last beyond it).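

Going from 4-(trifluoromethyl)piperidin-1-yl to 4-(difluoromethyl)piperidin-1-yl gives the first measured change at this position in this assay: a 1.3-fold higher number from compound 3 to compound 4 (0.12 log units; within the scatter). One fluoro can therefore be replaced by hydrogen here with no change that can be told apart from the spread of repeated measurements. Nothing measured here bears on why this step is so small.

Still open, as far as these compounds go, is how a methyl or a monofluoromethyl group would behave at this position. From the compounds shown here alone, an amine or a carboxylic acid in the same place is equally open.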